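From 4-Phenylphenyl to 6-Phenylpyridin-3-yl

This account rests on a few compounds, and the source may have more. Where it says the series, first, only, none or still open, it means among the compounds named here.

In a functional assay on HeLa cells (Homo sapiens) for inhibition, with a stated time of 72 h (a higher number here means a weaker inhibitor, a lower number a stronger inhibitor), compound 1 (`NC1CCC(Nc2nc(NCc3ccc(-c4ccccc4)cc3)c3ncn(C4CCCC4)c3n2)CC1`) gives 240 nM. Its only measured relative, compound 2 (`NC1CCC(Nc2nc(NCc3ccc(-c4cccc(F)c4)cc3)c3ncn(C4CCCC4)c3n2)CC1`), gives 445 nM, and these two values lie within the scatter of each other. Compound 3 (`NC1CCC(Nc2nc(NCc3ccc(-c4ccccc4)nc3)c3ncn(C4CCCC4)c3n2)CC1`) keeps the core of compound 1 but has 6-phenylpyridin-3-yl in place of 4-phenylphenyl on a saturated chain carbon bound to a nitrogen on an aromatic ring. Among the compounds with values here, the one measured step, a 1.9-fold higher number from compound 1 to compound 2 (0.27 log units; within the scatter), comes from fluoro in place of hydrogen on an aromatic carbon of that same group. Within the data shown here, it is a different change, and no measured compound carries 6-phenylpyridin-3-yl, so the evidence is thin. No step beyond the scatter is expected, and no direction can be firmly predicted. The expected step is a 1.3-fold higher number from compound 1 to compound 3 (0.10 log units; within the scatter). For compound 3 the estimated value is 300 nM, with an expected range of 110 nM to 800 nM.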

Compound 3, half-maximal inhibitory concentration: 114 nM
Estimate against measurement, compound 3: 2.6-fold (0.42 log units) above; the measured number falls inside the stated range.
By their numbers in this assay, from the lowest: compound 3; then compounds 1 and 2 (each within the scatter of the next).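

In this assay, 6-phenylpyridin-3-yl in place of 4-phenylphenyl gives a 2.1-fold lower number from compound 1 to compound 3 (0.32 log units; beyond the scatter), a modest step, and the first shown at this position that lies beyond the usual scatter. The group entering on the saturated chain carbon bound to a nitrogen on an aromatic ring keeps the same number of heavy atoms, but one carbon-only aromatic ring gives way to a six-membered aromatic ring with one hetero atom, and one hydrogen-bond acceptor enters. So this position responds to a change inside the aromatic ring itself, although no measurement available here gives a reason for the step.

From the compounds shown here alone, it remains open whether this lower number depends on that single ring nitrogen, which a pyrimidine ring in the same place would help to test. It is also unknown how an amine or a methoxy group on the phenyl ring of 6-phenylpyridin-3-yl would change the number.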